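Amine ring swap on the thiocarbonyl carbon of compound 1

A few compounds are considered here, and "the series" means these few. Any claim that something is new, unique, unknown or untested is made for them only; others in the source may bear on it.

Compound 1 `Nc1ccccc1NC(=O)c1ccc(CSC(=S)N2CCCc3ccccc32)cc1` gives 26.5% in a functional assay on A-375 cells (Homo sapiens) for antiproliferative activity, read by CCK-8 assay, with a stated time of 72 h, tested at 2 uM (a lower number here means a weaker effect, a higher number a stronger effect of the compound at the concentration tested), the lowest of the three numbers recorded. Compound 2 `Nc1ccccc1NC(=O)c1ccc(CSC(=S)N2CCN(Cc3cccnc3)CC2)cc1` gives 31.5%, which lies within the scatter of compound 1. Compound 3 `Nc1ccccc1NC(=O)c1ccc(CSC(=S)N2CCN(c3ccncc3)CC2)cc1` gives 85.7%, far beyond it. Among the compounds with values here, the only measured step, a number 54.2 percentage points higher from compound 2 to compound 3 (beyond the scatter), concerns the substituent on the amine nitrogen in a ring and does not touch the part changed here. Compound 4 `Nc1ccccc1NC(=O)c1ccc(CSC(=S)N2CCCC2)cc1` differs from compound 1 by pyrrolidin-1-yl in place of 1,2,3,4-tetrahydroquinolin-1-yl on a thiocarbonyl carbon. Within the data shown here, no measured step bears on this change, so nothing beyond the scatter is expected, and the weak level of compound 1 serves as the anchor. Compound 4 is estimated at 25%, with a range from 10% to 45%; the expected step of a number 1.5 percentage points lower from compound 1 to compound 4 (within the scatter) is taken to lie within the scatter.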

Compound 4, a percentage reported as inhibition, at one concentration (the size of the read-out at that concentration, not a potency): 30.2%
Compound 4: the middle estimate sits 5.2 percentage points below what was measured, within the range that was stated.
By their numbers in this assay, from the lowest: compounds 1, 4 and 2 (each within the scatter of the next); then compound 3.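

At the thiocarbonyl carbon, pyrrolidin-1-yl in place of 1,2,3,4-tetrahydroquinolin-1-yl gives a number 3.7 percentage points higher from compound 1 to compound 4 (within the scatter) in this assay. This first measured step at this position shows that a group of 5 heavy atoms with no aromatic ring reads level with the group of 10 heavy atoms that carries a six-membered aromatic ring. No supporting data bear on why the two groups read alike. Open, from the compounds shown here alone, is whether an open-chain amine such as diethylamino, or a morpholin-4-yl group, would stay at this level on the same carbon.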